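Adding a Chloro Group to a Pyrazoline-Pyrimidinone Antiproliferative

The source may report more compounds than this note shows. Statements on the series, on what has been measured and on what is new or still open speak of the compounds shown alone.

Measured compounds in a functional assay on A549 cells (Homo sapiens) for antiproliferative activity, with a stated time of 72 h; a higher number here means a weaker inhibitor, a lower number a stronger inhibitor: compound 1 `Cn1c(N2N=C(c3ccccc3)CC2c2ccc(Cl)cc2)nc(-c2ccccc2)c(C#N)c1=O` gives 3250 nM; compound 2 `Cn1c(N2N=C(c3ccccc3)CC2c2ccc(F)cc2)nc(-c2ccccc2)c(C#N)c1=O` gives 39200 nM; compound 3 `Cc1ccc(C2=NN(c3nc(-c4ccccc4)c(C#N)c(=O)n3C)C(c3ccc(F)cc3)C2)cc1` gives 2000 nM.

Compound 3 has the lowest number of the three, but its gap to compound 1 is within the scatter; only compound 2 stands clearly apart. Compound 4 `Cc1ccc(C2=NN(c3nc(-c4ccc(Cl)cc4)c(C#N)c(=O)n3C)C(c3ccc(F)cc3)C2)cc1` differs from compound 3 by chloro in place of hydrogen on an aromatic carbon. For the measured compounds named here, no measured step covers exactly this change. The closest guide is a 12-fold higher number from compound 1 to compound 2 (1.08 log units; beyond the scatter), where chloro beat fluoro on another ring, and a 20-fold lower number from compound 2 to compound 3 (1.29 log units; beyond the scatter) shows that small substituents can matter. A moderate drop in this assay is therefore expected, a 1.7-fold lower number from compound 3 to compound 4 (0.22 log units; within the scatter). Compound 4 is estimated at 1200 nM, within 400 nM to 4000 nM.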

Compound 4, half-maximal inhibitory concentration: 35600 nM
Estimate against measurement, compound 4: 30-fold (1.47 log units) below; the measured number lies above the stated range.
By their numbers in this assay, from the lowest: compounds 3 and 1 (each within the scatter of the next); then compounds 4 and 2 (each within the scatter of the next).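

Turning phenyl into 4-chlorophenyl, with the chloro para to a large group, gives an 18-fold higher number from compound 3 to compound 4 (1.25 log units; beyond the scatter) in this assay, so this position does not tolerate the change in this series. Chloro on another ring went with the lower number, as a 12-fold higher number from compound 1 to compound 2 (1.08 log units; beyond the scatter) shows when fluoro replaces it, so that result does not carry over to this ring. Nothing measured here explains the difference.

From the compounds shown here alone, it remains open whether fluoro, methoxy or an amine at this same position would keep the number low. Going by these compounds, whether the loss with chloro also appears on the core of compound 1 also remains open.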